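This account rests on a few compounds, and the source may have more. Where it says the series, first, only, none or still open, it means among the compounds named here.

Measured in a functional assay for inhibition; a lower number here means a stronger inhibitor, a higher number a weaker inhibitor
compound 1 `CC(C)(C)c1cc(-c2cc(=O)c3ccc(OCCO)cc3o2)cc(C(C)(C)C)c1O` gives 3000 nM
compound 2 `CC(C)(C)c1cc(-c2cc(=O)c3ccc(OCCCS(=O)(=O)O)cc3o2)cc(C(C)(C)C)c1O` gives 500 nM
compound 3 `CCOC(=O)C(C)(C)Oc1ccc2c(=O)cc(-c3cc(C(C)(C)C)c(O)c(C(C)(C)C)c3)oc2c1` gives 3000 nM

Compound 3 stands level with compound 1, the two sharing the highest number of the three, with no change at the digits printed from compound 1 to compound 3 (within the scatter) between them. Compound 2 stands apart, with a 6.0-fold higher number from compound 2 to compound 3 (0.78 log units; beyond the scatter) on the way back up. Next is compound 4 `CC(C)(C)c1cc(-c2cc(=O)c3ccc(O)cc3o2)cc(C(C)(C)C)c1O`, with hydrogen in place of 1-(ethoxycarbonyl)-1-methylethyl on an oxygen on an aromatic ring. Going by the values given here, no measured compound carries hydrogen there, so these two steps bear only indirectly: exchanges on that oxygen gave no change or a modest one. The expected change in this assay is a 1.5-fold lower number from compound 3 to compound 4 (0.18 log units; within the scatter), with no step beyond the scatter anticipated. For compound 4 the estimate is 2000 nM, with an expected range from 500 nM to 8000 nM.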

Compound 4, half-maximal inhibitory concentration: 1000 nM
Beside the measured number, compound 4's estimate is 2.0-fold (0.30 log units) above it; measured number inside the range.
By their numbers in this assay, from the lowest: compounds 2 and 4 (each within the scatter of the next); then compounds 1 and 3 (each within the scatter of the next).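

Hydrogen on this oxygen gives the series its unsubstituted reference in this assay and shows a 3.0-fold lower number from compound 3 to compound 4 (0.48 log units; beyond the scatter) and a 3.0-fold lower number from compound 1 to compound 4 (0.48 log units; beyond the scatter) here, so 1-(ethoxycarbonyl)-1-methylethyl and 2-hydroxyethyl both read weaker than the free hydroxy. The 3-sulfopropyl chain shows a 2.0-fold higher number from compound 2 to compound 4 (0.30 log units; within the scatter) here, so it cannot be told apart from hydrogen and its edge over 2-hydroxyethyl is no gain over the free hydroxy. Nothing measured explains these differences.

Open, on these data alone, is whether a carboxylic acid or an amine at the end of a propyl chain on this oxygen would read like 3-sulfopropyl or like 2-hydroxyethyl.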